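Swapping Methoxy Groups for a Dimethylamino Arm

The source may hold more compounds than are shown below. What is called first, only, known or untested is meant among the compounds shown, and "the series" means these compounds.

Of the compounds shown here, two have so far been measured in a functional assay on the whole organism (strain Wistar) for inhibition, with Rattus norvegicus as the target, read by paw edema, with a stated time of 4 h, at a dose of 10 mg/kg by the intraperitoneal route; a higher number here means more inhibition at the dose given (going by the name of the read-out), a lower number less inhibition. Compound 1 `COc1cccc(/C=N/NC(=O)c2cccnc2Nc2cccc(C(F)(F)F)c2)c1` gives 14.9% in this assay. Compound 2 `COc1ccc(/C=N/NC(=O)c2cccnc2Nc2cccc(C(F)(F)F)c2)c(OC)c1` gives 19.8% in this assay. These two numbers lie within the usual scatter of each other, so the measurements so far do not set compound 2 apart from compound 1. For the measured compounds named here, the only step between measured compounds, a number 4.9 percentage points higher from compound 1 to compound 2 (within the scatter), exchanged one methoxy-bearing aromatic group for another on the carbon with a double bond to nitrogen and left the read-out essentially unchanged.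

Compound 3 `CN(C)c1ccc(/C=N/NC(=O)c2cccnc2Nc2cccc(C(F)(F)F)c2)cc1` is built on the same core and differs from compound 2 in one place: 4-(dimethylamino)phenyl in place of 2,4-dimethoxyphenyl on a carbon with a double bond to nitrogen. The step between the two measured compounds is the only one that bears on this change, and it bears only loosely, since it exchanged aromatic groups at the same carbon but did not involve a dimethylamino group. No measurement shows what that group does here. With only a within-scatter step to go on, the expected step from compound 2 to compound 3 is a number 1.8 percentage points lower from compound 2 to compound 3 (within the scatter), nothing beyond the scatter. Compound 3 is therefore estimated to give 18% in this assay. The estimate for compound 3 is expected to fall between 5% and 35%.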

Compound 3, a percentage reported as inhibition, in the whole organism at one dose (the size of the read-out at that dose, not a potency): 28.2%
For compound 3 the middle estimate is 10.2 percentage points below the measured one, within the range that was stated.
By their numbers in this assay, from the lowest: compounds 1, 2 and 3 (each within the scatter of the next, the first and the last beyond it).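

The aromatic group on the carbon with a double bond to nitrogen is now seen to move the read-out in this assay, though only one of the two new steps shows this. Placing 4-(dimethylamino)phenyl where 2,4-dimethoxyphenyl stood gives a number 8.4 percentage points higher from compound 2 to compound 3 (within the scatter) and so does not set these two compounds apart, while placing it where 3-methoxyphenyl stood gives a number 13.3 percentage points higher from compound 1 to compound 3 (beyond the scatter) and is the first step here to pass the usual scatter, if only modestly. The earlier pair could not show that this position responds at all, but nothing measured explains why the dimethylamino compound separates from one methoxy compound and not from the other.

From the compounds shown here alone, it remains open how the read-out would respond to other groups on this phenyl ring, such as a primary amine or a carboxylic acid, or to longer chains on the nitrogen in place of the two methyl groups. Going by these compounds, the three compounds also share the rest of their structure and were compared at a single dose and time, so the contribution of the trifluoromethyl-bearing part and the behaviour at other doses stay unknown.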